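This account rests on a few compounds, and the source may have more. Where it says the series, first, only, none or still open, it means among the compounds named here.

Measured compounds:
compound 1, `CCN(C/C=C/C#CC(C)(C)C)Cc1cccc(OCCNS(=O)(=O)c2cccs2)c1` — 450 nM
compound 2, `CCN(C/C=C/C#CC(C)(C)C)Cc1cccc(OCCN(C)S(=O)(=O)c2ccsc2)c1` — 250 nM
compound 3, `CCN(C/C=C/C#CC(C)(C)C)Cc1cccc(OCCN(C)S(=O)(=O)c2cc(Br)cs2)c1` — 300 nM

These three compounds share one core and differ only at the sulfonamide end. In a functional assay on HepG2 cells for inhibition of squalene monooxygenase (Homo sapiens) (on this read-out lower numbers stand for stronger inhibition and higher numbers for weaker inhibition), compound 1 gives the highest of the three numbers, yet neither of its neighbours is separated from it by more than the scatter: a 1.8-fold lower number from compound 1 to compound 2 (0.26 log units; within the scatter) and a 1.5-fold lower number from compound 1 to compound 3 (0.18 log units; within the scatter). Between the two methylated analogues, a 1.2-fold higher number from compound 2 to compound 3 (0.08 log units; within the scatter).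

Compound 4, `CCN(C/C=C/C#CC(C)(C)C)Cc1cccc(OCCN(C2CC2)S(=O)(=O)c2cccs2)c1`, keeps the thiophene of compound 1 and changes only the sulfonamide nitrogen: cyclopropyl in place of hydrogen on a sulfonamide nitrogen. Among the compounds with values here, the only measured steps that touch this nitrogen are those from compound 1 to compound 2 and to compound 3, where a methyl replaces the hydrogen at the same time as the thiophene is altered; both steps stayed within the scatter. A cyclopropyl in place of hydrogen at that nitrogen is therefore expected to produce no step beyond the scatter in this assay, with whatever movement there is leaning toward a lower number as in the two measured steps.

Compound 4 is accordingly estimated at 350 nM, within 150 nM to 900 nM, which would mean an expected step of a 1.3-fold lower number from compound 1 to compound 4 (0.11 log units; within the scatter).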

Compound 4, half-maximal inhibitory concentration: 230 nM
Compound 4: middle estimate off by 1.5-fold (0.18 log units), on the high side, within the range that was stated.
By their numbers in this assay, from the lowest: compounds 4, 2, 3 and 1 (each within the scatter of the next).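

Within the data shown here, compound 4 gives the first step in which the sulfonamide nitrogen is the only thing that changes, since the steps to compound 2 and compound 3 altered the thiophene as well. In this assay, cyclopropyl in place of hydrogen on this nitrogen stays within the scatter (a 2.0-fold lower number from compound 1 to compound 4 (0.29 log units; within the scatter)), so losing the hydrogen of the sulfonamide nitrogen and gaining a three-membered ring of carbon does not separate the two compounds on this read-out. Nothing at hand accounts for this result, and it says only that this one replacement leaves the number within the scatter of that of compound 1.

The compounds shown leave open whether a group such as benzyl, a longer chain such as n-butyl, or a chain ending in an amine or a carboxylic acid on this nitrogen would also stay within the scatter. They also leave open how a methyl on this nitrogen compares with hydrogen when the thiophene of compound 1 is kept, and whether cyclopropyl behaves the same way with the thiophen-3-yl of compound 2 or the 4-bromothiophen-2-yl of compound 3 on the sulfonyl sulfur.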